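The source may hold more compounds than are shown below. What is called first, only, known or untested is meant among the compounds shown, and "the series" means these compounds.

Measured compounds:
compound 1 `CN(C)CCn1cnnc1-c1cc(Oc2ccc(NC(=O)N/N=C/c3c[nH]c4ccccc34)cc2F)ccn1` — 1630 nM
compound 2 `COc1ccc(/C=N/NC(=O)Nc2ccc(Oc3ccnc(-c4nncn4CCN(C)C)c3)c(F)c2)c(OC)c1OC` — 1790 nM
compound 3 `CN(C)CCn1cnnc1-c1cc(Oc2ccc(NC(=O)N/N=C/c3ccccc3)cc2F)ccn1` — 1780 nM

All three share one core and differ only in the aryl group on the carbon with a double bond to nitrogen. In a functional assay on NCI-H460 cells (Homo sapiens) for cytotoxicity, read by MTT assay, with a stated time of 72 h (a higher number here means a weaker inhibitor, a lower number a stronger inhibitor), compound 3 gives 1780 nM, the second highest of the three numbers, though every gap among them lies within the scatter: a 1.1-fold higher number from compound 1 to compound 3 (0.04 log units; within the scatter), a 1.0-fold lower number from compound 2 to compound 3 (0.00 log units; within the scatter), a 1.1-fold higher number from compound 1 to compound 2 (0.04 log units; within the scatter).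

Compound 4 `Cn1ncnc1-c1cc(Oc2ccc(NC(=O)N/N=C/c3ccccc3)cc2F)ccn1` is not yet measured. Against compound 3 it carries 1-methyl-1H-1,2,4-triazol-5-yl in place of 4-(2-(dimethylamino)ethyl)-4H-1,2,4-triazol-3-yl on an aromatic carbon. Going by the values given here, none of the measured steps touches this position; all three vary the aryl group on the carbon with a double bond to nitrogen and leave the triazole unchanged. Among the compounds with values here, there is therefore no measured step that bears on the change from compound 3 to compound 4, and no direction can be read from the series. The working expectation is a number near that of compound 3, with wide uncertainty: compound 4 is estimated at 2500 nM (range 700 nM to 9000 nM), an expected step of a 1.4-fold higher number from compound 3 to compound 4 (0.15 log units; within the scatter).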

Compound 4, half-maximal inhibitory concentration: 52200 nM
Beside the measured number, compound 4's estimate is 21-fold (1.32 log units) below it; the measured number lies above the stated range.
By their numbers in this assay, from the lowest: compounds 1, 3 and 2 (each within the scatter of the next); then compound 4.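

In this assay the triazole position proves far more sensitive than the aryl group on the carbon with a double bond to nitrogen: changes to that aryl group among compound 1, compound 2 and compound 3 all stay within the scatter, whereas this single replacement gives a 29-fold higher number from compound 3 to compound 4 (1.47 log units; beyond the scatter) in a direction and size those steps could not show. The replacement changes both the side chain and the triazole isomer, while each group remains a five-membered aromatic ring with 3 hetero atoms. No measured evidence accounts for the step.

The compounds shown do not separate the contribution of the 2-(dimethylamino)ethyl chain from that of the triazole isomer. A 4-methyl-4H-1,2,4-triazol-3-yl group would divide the two, and a morpholine at the chain end would test whether the dimethylamino group itself matters.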